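Truncating the amine-bearing side chain of compound 1

The source may hold more compounds than are shown below. What is called first, only, known or untested is meant among the compounds shown, and "the series" means these compounds.

Compound 1 `c1cncc(CNCCCCN(C[C@H]2Cc3ccccc3CN2)[C@H]2CCCc3cccnc32)c1` gives the lowest number among the three measured compounds in a functional assay on cells for antagonist activity at C-X-C chemokine receptor type 4 (Homo sapiens), read by fluorescence and calcium flux, with stated times of 25 min and 90 s (on this read-out lower numbers stand for stronger inhibition and higher numbers for weaker inhibition), at 15.3 nM. Compound 2 `c1ccc2c(c1)CN[C@@H](CN(CCCCNCc1ccncc1)[C@H]1CCCc3cccnc31)C2` gives 22.7 nM, a step of a 1.5-fold higher number from compound 1 to compound 2 (0.17 log units; within the scatter), and compound 3 `c1ccc2c(c1)CN[C@@H](CN(CCCCNC1CCNCC1)[C@H]1CCCc3cccnc31)C2` gives 63.4 nM, a step of a 4.1-fold higher number from compound 1 to compound 3 (0.62 log units; beyond the scatter). Compound 4 `CC(C)(CN)CCN(C[C@H]1Cc2ccccc2CN1)[C@H]1CCCc2cccnc21` differs from compound 1 by 1-(aminomethyl)-1-methylethyl in place of 2-(((pyridin-3-yl)methyl)amino)ethyl on a saturated chain carbon, two bonds along the chain from an amine nitrogen. For the measured compounds named here, no measured step removes the aromatic ring together with part of the chain, but the swap to piperidin-4-yl in compound 3, with its step of a 4.1-fold higher number from compound 1 to compound 3 (0.62 log units; beyond the scatter) from compound 1 and a 2.8-fold higher number from compound 2 to compound 3 (0.45 log units; beyond the scatter) from compound 2, shows that moving away from the (pyridin-3-yl)methyl group costs modestly. Compound 4 is therefore expected to show a step of a 5.2-fold higher number from compound 1 to compound 4 (0.72 log units; beyond the scatter), giving an estimated 80 nM with a range of 25 nM to 300 nM.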

Compound 4, half-maximal inhibitory concentration: 69 nM
For compound 4 the middle estimate is 1.2-fold (0.06 log units) above the measured one, within the range that was stated.
By their numbers in this assay, from the lowest: compounds 1 and 2 (each within the scatter of the next); then compounds 3 and 4 (each within the scatter of the next).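

In this assay, the position tolerates losing the aromatic ring along with part of the chain at only a modest cost: 1-(aminomethyl)-1-methylethyl gives a 4.5-fold higher number from compound 1 to compound 4 (0.65 log units; beyond the scatter) and a 3.0-fold higher number from compound 2 to compound 4 (0.48 log units; beyond the scatter). This small group without a ring also matches the piperidin-4-yl side chain, at a 1.1-fold higher number from compound 3 to compound 4 (0.04 log units; within the scatter), so a ring on the side chain is not required for activity at this level. No available evidence accounts for these steps.

The compounds shown leave open whether the branching matters, as an unbranched 4-aminobutyl chain would test. They also leave open whether a carboxylic acid could replace the terminal amine.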